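This account rests on a few compounds, and the source may have more. Where it says the series, first, only, none or still open, it means among the compounds named here.

In a physicochemical assay for solubility, using the shake flask method, in simulated intestinal fluid, measured as kinetic solubility, with a stated time of 2 h, at 25 degrees C, at pH 6.5 (on this read-out lower numbers stand for lower solubility and higher numbers for higher solubility), compound 3 `COc1ccccc1CN1C(=O)c2c(C)nc(-c3nc(C)no3)c(N)c2C1=O` gives < 5000 nM, which is a limit and not a number. Compound 1 `Cc1noc(-c2nc(C)c3c(c2N)C(=O)N(Cc2ccc(-c4ccncc4)cc2)C3=O)n1` gives < 5000 nM, also a limit. Compound 2 `Cc1noc(-c2nc(C)c3c(c2N)C(=O)N(Cc2cccc(F)c2)C3=O)n1` gives < 5000 nM, again a limit. Within the data shown here, the series therefore offers no numerical value so far, only (the limit of < 5000 nM in this assay, at which 3 of the 3 values shown sit).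

Compound 4 `Cc1noc(-c2nc(C)c3c(c2N)C(=O)N(Cc2ccc(OC(F)F)cc2)C3=O)n1` differs from compound 3 at one place: 4-(difluoromethoxy)phenyl in place of 2-methoxyphenyl on a saturated chain carbon bound to an amide-type nitrogen in a ring. The substituted phenyl group on the saturated chain carbon has been changed once before among the measured compounds, and that change is a step that the two limits leave unreadable from compound 2 to compound 3. It gives no size or direction to carry over to the new group.

Among the measured compounds shown here, with only that step as a guide, no step beyond the scatter is expected in this assay, in either direction, and compound 4 will most likely be reported as a limit too. The expected step is a step that the limit leaves unreadable from compound 3 to compound 4. For compound 4 the estimated value is 2500 nM, with an expected range from 700 nM to 5000 nM.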

Compound 4, solubility: < 5000 nM
Compound 4 ended at the assay's limit; the forecaster's own chance of this, stated with the estimate: 85%; the middle value does not contradict the limit.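

In this assay compound 4 gives < 5000 nM, a limit and not a number. Among these compounds, no step to compound 4 from compound 1, compound 2 or compound 3 can be read. The compounds shown leave open whether their solubilities differ at all: the limit of < 5000 nM in this assay, at which 4 of the 4 values shown sit.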